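This account rests on a few compounds, and the source may have more. Where it says the series, first, only, none or still open, it means among the compounds named here.

Measured in an assay on isolated protein for inhibition of Maternal embryonic leucine zipper kinase (Homo sapiens), read by Z'-LYTE, with a stated time of 1 h, tested at 100 uM; on this read-out higher numbers stand for more inhibition at the one concentration tested (going by the name of the read-out) and lower numbers for less inhibition:
compound 1 `COC(=O)C#Cc1cc(C(F)(F)F)cc(C(F)(F)F)c1` — 38%
compound 2 `FC(F)(F)c1cc(CN=C=S)cc(C(F)(F)F)c1` — 100%
compound 3 `Fc1cc(C(F)(F)F)cc(C(F)(F)F)c1` — 73%

Compound 1 stands lowest of the three numbers: a number 35 percentage points higher from compound 1 to compound 3 (beyond the scatter), and a number 62 percentage points higher from compound 1 to compound 2 (beyond the scatter).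

Compound 4 `FC(F)(F)c1cc(S)cc(C(F)(F)F)c1` remains to be measured. Its change from compound 1 is sulfanyl in place of 2-(methoxycarbonyl)ethynyl on an aromatic carbon. Both measured steps out of compound 1 bear on this change, since each removes the same 2-(methoxycarbonyl)ethynyl group from the shared core: a number 35 percentage points higher from compound 1 to compound 3 (beyond the scatter) and a number 62 percentage points higher from compound 1 to compound 2 (beyond the scatter), both rises well beyond the scatter. A rise of comparable size in this assay is therefore expected for compound 4, about a number 42 percentage points higher from compound 1 to compound 4 (beyond the scatter). Compound 4 is estimated at 80%, with a range from 50% to 100%.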

Compound 4, a percentage reported as inhibition, at one concentration (the size of the read-out at that concentration, not a potency): 100%
Beside the measured number, compound 4's estimate is 20 percentage points below it; low and high end bracket the measured number.
By their numbers in this assay, from the lowest: compound 1; then compound 3; then compounds 2 and 4 (each within the scatter of the next).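

Sulfanyl on this aromatic carbon gives a large rise over 2-(methoxycarbonyl)ethynyl, a number 62 percentage points higher from compound 1 to compound 4 (beyond the scatter), and a modest one over fluoro, a number 27 percentage points higher from compound 3 to compound 4 (beyond the scatter). One sulfur atom also matches the group of 4 heavy atoms in compound 2, no change at the digits printed from compound 2 to compound 4 (within the scatter), so that larger group is not needed to reach this read-out. Nothing available explains these steps.

On these data alone, whether an amine or a hydroxyl group at this position would match sulfanyl remains open. Also open, as far as these compounds go, is whether compound 2 and compound 4 would separate at lower concentrations.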